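The source may report more compounds than this note shows. Statements on the series, on what has been measured and on what is new or still open speak of the compounds shown alone.

Measured so far in a functional assay on RPMI-8226 cells (Homo sapiens) for cytotoxicity, read by sulforhodamine B assay, with a stated time of 48 h; on this read-out higher numbers stand for lower toxicity in this test and lower numbers for higher toxicity in this test:

Compound 1, `ClCc1cccc(Cn2cnc3c(Cl)nc(Cl)nc32)c1`, gives > 100000 nM, which is a limit of the assay and not a number.
Compound 2, `Nc1nc(Cl)c2ncn(Cc3ccccc3CCl)c2n1`, gives > 100000 nM, again a limit of the assay rather than a number.
Compound 3, `ClCc1ccc(Cn2cnc3c(Cl)nc(Cl)nc32)cc1`, gives "not determined" (no result reported) in this assay.

Compound 1 therefore stands on a limit only: the numbers shown hold one further limit and one entry without a single number, so no measured step exists between any two of these compounds, and no ordering among them can be drawn. What the shown values do establish is the limit of > 100000 nM in this assay, at which 2 of the 3 values shown sit. Compound 2, which carries an amino group on its core, sits at that same limit as compound 1.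

Compound 4, `Nc1nc(Cl)c2ncn(Cc3cccc(CCl)c3)c2n1`, is the next compound to be measured in this assay. It differs from compound 1 in one place: amino in place of chloro on an aromatic carbon. Among the compounds with values here, since no measured step is on hand, the expectation for the step from compound 1 to compound 4 is none beyond the scatter, with compound 1 at the limit and compound 2 at the same limit as the only guides. The estimated step that the limit leaves unreadable from compound 1 to compound 4 is accordingly flat. Compound 4 is expected to give 150000 nM, within a range of 50000 nM to 500000 nM, most likely reported as a limit.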

Compound 4, concentration lethal to 50% of the cells: > 100000 nM
Compound 4 was reported as a limit (the forecaster's own chance of this, stated with the estimate: 80%); the middle value is on the limit's open side.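

In this assay compound 4 gives > 100000 nM as a limit of the assay and not a number. Within the data shown here, compound 1 also stands at a limit, so no step between compound 1 and compound 4 can be read: the limit of > 100000 nM in this assay, at which 3 of the 4 values shown sit. The compounds shown leave open whether amino in place of chloro changes toxicity in this test at all.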